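The source may report more compounds than this note shows. Statements on the series, on what has been measured and on what is new or still open speak of the compounds shown alone.

Measured so far in a functional assay on NALM-6 cells (Homo sapiens) for cytotoxicity, with a stated time of 72 h; on this read-out higher numbers stand for an effect only at larger amounts of compound and lower numbers for an effect already at smaller amounts:
- compound 1 `C=C[C@@](C)(/C=C/c1ccc(O)cc1)CC/C=C(C)/C=N/N`: > 43400 nM
- compound 2 `COc1ccc(/C=C/[C@@](C)(/C=C/c2ccc(O)c(C=O)c2)CCC=C(C)C)cc1`: > 43400 nM

Compound 1 gives > 43400 nM, which is a limit of the assay and not a number. Compound 2 gives > 43400 nM, which is likewise only a limit. Among the measured compounds shown here, the series so far therefore rests on (the limit of > 43400 nM in this assay, at which 2 of the 2 values shown sit), and no numerical value is available for either compound.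

The next compound is compound 3 `CCOC(=O)/C(C)=C/c1cc(/C=C/[C@](C)(/C=C/c2ccc(OC)cc2)CCC=C(C)C)ccc1O`. Compared with compound 2, it has 2-(ethoxycarbonyl)prop-1-en-1-yl in place of formyl on an aromatic carbon, ortho to a hydroxy group (2-(ethoxycarbonyl)prop-1-en-1-yl in place of formyl on an aromatic carbon).

For the measured compounds named here, no step between measured compounds is available to size this change. A change beyond the usual scatter is therefore not expected in this assay, in either direction. This expectation rests on compound 2 at > 43400 nM, again a limit. Compound 3 may well also return only a limit.

The estimated change is an at least 1.0-fold lower number from compound 2 to compound 3 (0.03 log units; that floor lies within the scatter). For compound 3 the estimated value is 40000 nM, with an expected range of 12000 nM to 60000 nM.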

Compound 3, half-maximal effective concentration: > 43400 nM
Compound 3: no number, only a limit; the forecaster's own chance of this, stated with the estimate: 65%; middle value at least 1.0-fold (0.03 log units) from the limit.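

In this assay compound 3 gives > 43400 nM as a limit and not a number. Compound 2 also stands only at a limit, so no step can be read between compound 2 and compound 3, and the series rests on a single limit: the limit of > 43400 nM in this assay, at which 3 of the 3 values shown sit.

The compounds shown leave open whether any change on the shared core gives a numerical value on this read-out.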